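The compounds below may be only part of what the source reports. "The series", "measured", "known", "first", "only" and "open" are said of these compounds alone.

Three compounds have been measured in an ADME assay on microsomes from liver (Homo sapiens) for metabolic stability, read by LC-MS, using NADPH, tested at 5 uM; a lower number here means that the compound disappears faster, a higher number that the compound lasts longer:
compound 1 `Cc1cc(S(=O)(=O)/N=C(\N)n2nccc2-c2ccccc2)c(SCc2ccccc2Cl)cc1Cl` gives 0.226 h;
compound 2 `Cc1cc(-c2ccccc2)n(/C(N)=N/S(=O)(=O)c2cc(C)c(Cl)cc2SCc2ccccc2C(F)(F)F)n1` gives 0.306 h;
compound 3 `Cc1cc(S(=O)(=O)/N=C(\N)n2nccc2-c2ccccc2)c(SCc2cccc(Cl)c2)cc1Cl` gives 0.309 h.

Compound 2 has the second highest of the three numbers, but its nearest neighbour is compound 3, with a gap within the scatter, and even the furthest, compound 1, lies within the scatter of compound 2. Within the data shown here, the three numbers thus form one tight group, with no compound clearly set apart.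

Compound 4 `Cc1cccc(CSc2cc(Cl)c(C)cc2S(=O)(=O)/N=C(\N)n2nc(C)cc2-c2ccccc2)c1` has not yet been measured. It differs from compound 2 in one place: 3-methylphenyl in place of 2-(trifluoromethyl)phenyl on a saturated chain carbon bound to a sulfur. Among the measured compounds shown here, the only measured step at the same place is the one in which 3-chlorophenyl replaced 2-chlorophenyl on a saturated chain carbon bound to a sulfur, giving a 1.4-fold higher number from compound 1 to compound 3 (0.14 log units; within the scatter), a step within the scatter. That step changed only where a chlorine sits, whereas the present change swaps the whole group, so the measured data bear on it only loosely. Nothing measured here points to a shift beyond the scatter, so the expected step for compound 4 is a 1.0-fold lower number from compound 2 to compound 4 (0.01 log units; within the scatter), with no clear direction. Compound 4 is therefore estimated to give 0.3 h in this assay, in a range from 0.15 h to 0.6 h.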

Compound 4, half-life: 0.214 h
Beside the measured number, compound 4's estimate is 1.4-fold (0.15 log units) above it; low and high end bracket the measured number.
By their numbers in this assay, from the lowest: compounds 4, 1, 2 and 3 (each within the scatter of the next).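

In this assay, replacing 2-(trifluoromethyl)phenyl with 3-methylphenyl on a saturated chain carbon bound to a sulfur gives a 1.4-fold lower number from compound 2 to compound 4 (0.16 log units; within the scatter). The earlier step at this place only moved a chlorine around the same phenyl group, whereas this one exchanges the whole group, going from 10 heavy atoms to 7 and losing all the fluorine, and it too stays within the scatter, so the half-life at this place has now withstood a broader kind of exchange than a shifted chlorine. Nothing else measured here bears on this result, so no reason for it can be offered.

Every group shown at this place is still a phenyl ring carrying a chlorine, a trifluoromethyl or a methyl, so it remains open whether a group of another kind, such as an amine or a carboxylic acid on that ring, or a saturated ring in place of the phenyl, would give a step beyond the scatter. Also open, as far as these compounds go, is whether a longer chain between the sulfur and the ring would do so.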